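The source may report more compounds than this note shows. Statements on the series, on what has been measured and on what is new or still open speak of the compounds shown alone.

Measured so far:
Compound 1 `O=C(O)CCc1ccc(OCc2nnc(C(=O)Nc3ccccc3F)s2)cc1` — 580 nM
Compound 2 `O=C(O)CCc1ccc(OCc2nnc(C(=O)Nc3ccc(F)cc3)s2)cc1` — 6640 nM
Compound 3 `Cc1ccccc1NC(=O)c1nnc(COc2ccc(CCC(=O)O)cc2)s1` — 1520 nM

All three share the same core and differ only in the ring attached to the amide nitrogen. In a functional assay on CHO cells for agonist activity at Free fatty acid receptor 1 (Homo sapiens), read by calcium flux (a lower number here means that less compound is needed, a higher number that more compound is needed for the effect), compound 1 gives 580 nM, the lowest number of the three, while compound 2 gives 6640 nM, the highest. Compound 3, with 1520 nM, stands second highest: the step of a 2.6-fold higher number from compound 1 to compound 3 (0.42 log units; beyond the scatter) separates it from compound 1, and the step of a 4.4-fold lower number from compound 2 to compound 3 (0.64 log units; beyond the scatter) from compound 2.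

Compound 4 `O=C(O)CCc1ccc(OCc2nnc(C(=O)Nc3cccc(F)c3)s2)cc1` has not been measured. It differs from compound 3 by 3-fluorophenyl in place of 2-methylphenyl on an amide-type nitrogen. Among the measured compounds shown here, two measured steps bear on this: an 11-fold higher number from compound 1 to compound 2 (1.06 log units; beyond the scatter) shows that moving the fluoro from the 2-position to the 4-position raises the number strongly, and a 4.4-fold lower number from compound 2 to compound 3 (0.64 log units; beyond the scatter) places the 2-methylphenyl between the two fluorophenyls. For the measured compounds named here, a 3-fluorophenyl has no direct precedent here, so a number between those of compound 1 and compound 2 is expected, close to compound 3, with the step of a 1.3-fold higher number from compound 3 to compound 4 (0.12 log units; within the scatter) estimated to stay within or only slightly beyond the scatter. Compound 4 is therefore estimated at 2000 nM, with a range from 600 nM to 7000 nM.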

Compound 4, half-maximal effective concentration: 1190 nM
Compound 4: middle estimate off by 1.7-fold (0.23 log units), on the high side; measured number inside the range.
By their numbers in this assay, from the lowest: compound 1; then compounds 4 and 3 (each within the scatter of the next); then compound 2.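

In this assay the three fluorophenyl groups on the amide-type nitrogen can now be set in order, since 3-fluorophenyl gives a 2.1-fold higher number from compound 1 to compound 4 (0.31 log units; beyond the scatter) and also a 5.6-fold lower number from compound 2 to compound 4 (0.75 log units; beyond the scatter) so the number climbs from 2-fluorophenyl through 3-fluorophenyl to 4-fluorophenyl. Exchanging 2-methylphenyl for 3-fluorophenyl gives a 1.3-fold lower number from compound 3 to compound 4 (0.11 log units; within the scatter) so these two groups cannot be told apart here, although both the substituent and its place on the ring differ. Nothing available explains why the place of the fluoro changes the number.

From the compounds shown here alone, whether methyl follows the same order as fluoro, with 3-methylphenyl and 4-methylphenyl, remains open. So does the outcome with a chloro, a methoxy or an amine on this ring, or with two fluoro groups together.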